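The source may report more compounds than this note shows. Statements on the series, on what has been measured and on what is new or still open speak of the compounds shown alone.

Of the compounds shown here, two have so far been measured in an assay on isolated protein for displacement of a labelled ligand from Apoptosis regulator Bcl-2 (Homo sapiens), with a stated time of 15 min; a higher number here means a weaker inhibitor, a lower number a stronger inhibitor. Compound 1 `CC1(C)CCC(CN2CCN(c3ccc(C(=O)NS(=O)(=O)c4ccc(NCC5CCOCC5)c([N+](=O)[O-])c4)c(Oc4cnc5[nH]ccc5c4)c3)CC2)=C(c2ccccc2C(F)(F)F)C1` gives 1.7 nM. Compound 2 `CC1(C)CCC(CN2CCN(c3ccc(C(=O)NS(=O)(=O)c4ccc(NCC5CCOC5)c([N+](=O)[O-])c4)c(Oc4cnc5[nH]ccc5c4)c3)CC2)=C(c2ccc(C(F)(F)F)cc2)C1` gives 4.7 nM, the higher of the two numbers, so compound 2 is the weaker inhibitor of the pair. Compound 3 `CC1(C)CCC(CN2CCN(c3ccc(C(=O)NS(=O)(=O)c4ccc(OCC5CCCOC5)c([N+](=O)[O-])c4)c(Oc4cnc5[nH]ccc5c4)c3)CC2)=C(c2ccc(C(F)(F)F)cc2)C1` has not been measured; it differs from compound 2 in one place: a group of 8 heavy atoms (6 carbon, 2 oxygen; one six-membered non-aromatic ring with 1 hetero atom) in place of a group of 7 heavy atoms (5 carbon, 1 nitrogen, 1 oxygen; one five-membered non-aromatic ring with 1 hetero atom), on an aromatic carbon. Within the data shown here, no single-change step between measured compounds covers this kind of change, so the expectation rests on compound 2 alone. Compound 3 is expected to be a somewhat weaker inhibitor, with the step of a 2.1-fold higher number from compound 2 to compound 3 (0.33 log units; beyond the scatter) modest but probably beyond the scatter. The estimate for compound 3 is 10 nM, with a range from 3 nM to 40 nM.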

Compound 3, half-maximal inhibitory concentration: 3 nM
Beside the measured number, compound 3's estimate is 3.3-fold (0.52 log units) above it, within the range that was stated.
By their numbers in this assay, from the lowest: compounds 1, 3 and 2 (each within the scatter of the next, the first and the last beyond it).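

Replacing the ((oxolan-3-yl)methyl)amino group with the larger group, which has a six-membered ring and 0 hydrogen-bond donors, gives a 1.6-fold lower number from compound 2 to compound 3 (0.19 log units; within the scatter) in this assay and so leaves the number within the scatter. At this position, on an aromatic carbon ortho to a nitro group, the result therefore does not depend on keeping the hydrogen-bond donor of compound 2. No measurement offered here explains this result.

Ring size and the linking atom change together in this step, so their separate contributions remain open. From the compounds shown here alone, how a piperidine ring or a plain butyl chain would fare at this position also remains open.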